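This account rests on a few compounds, and the source may have more. Where it says the series, first, only, none or still open, it means among the compounds named here.

Compound 2 `CC(O)(C[S+]([O-])c1ccccn1)C(=O)Nc1ccc([N+](=O)[O-])cc1C(F)(F)F` stands at the limit of > 100000 nM in this assay, at which 1 of the 2 values shown sits. In a functional assay on CWR22R cells (Homo sapiens) for antiproliferative activity (a lower number here means a stronger inhibitor, a higher number a weaker inhibitor), compound 2 gives > 100000 nM, a limit of the assay and not a number. Compound 1 `CC(O)(C[S+]([O-])c1ccc(C(F)(F)F)cc1)C(=O)Nc1ccc([N+](=O)[O-])cc1C(F)(F)F` in this assay gives 21100 nM. For the measured compounds named here, the single measured step, an at least 4.7-fold higher number from compound 1 to compound 2 (0.67 log units; beyond the scatter), is the only guide. Compound 3 `CC(O)(C[S+]([O-])c1ccc(OC(F)(F)F)cc1)C(=O)Nc1ccc([N+](=O)[O-])cc1C(F)(F)F` arises from compound 2 by 4-(trifluoromethoxy)phenyl in place of pyridin-2-yl on a sulfur, which runs against the direction of that step, a six-membered aromatic ring of carbon only again replacing pyridin-2-yl. A decrease of comparable size is therefore expected, an at least 5.0-fold lower number from compound 2 to compound 3 (0.69 log units; beyond the scatter), its exact extent open since compound 2 is only a limit. Compound 3 is estimated at 20000 nM, between 7000 nM and 70000 nM.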

Compound 3, half-maximal inhibitory concentration: > 100000 nM
Compound 3 gave a limit, no number (the forecaster's own chance of this, stated with the estimate: 20%); middle value at least 5.0-fold (0.69 log units) from the limit.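

A carbon-only aromatic ring on the sulfur is not enough to keep a measurable value in this assay, since trifluoromethoxy in place of trifluoromethyl on an aromatic carbon gives an at least 4.7-fold higher number from compound 1 to compound 3 (0.67 log units; beyond the scatter). Compound 3 at > 100000 nM is a limit of the assay and not a number. The step between compound 2 and compound 3 therefore cannot be read, and the shown values crowd at the top of the range: the limit of > 100000 nM in this assay, at which 2 of the 3 values shown sit.

From the compounds shown here alone, how far compound 2 and compound 3 lie past this limit stays open. Also open, going by these compounds, is whether an amine or a carboxylic acid in place of the trifluoromethyl of compound 1 would give a number at all.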